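Working notes: propylsulfanyl in place of methylsulfanyl

This account rests on a few compounds, and the source may have more. Where it says the series, first, only, none or still open, it means among the compounds named here.

- compound 1 `C=CCSS/C=C/C[S+]([O-])CCC` gives 37000 nM in a functional assay on WHCO1 cells (Homo sapiens) for antiproliferative activity, read by MTT assay, with a stated time of 48 h; a lower number here means a stronger inhibitor, a higher number a weaker inhibitor
- compound 2 `CCC[S+]([O-])C/C=C/SSC` gives 28000 nM in this assay

Compound 2 at 28000 nM lies within the scatter of compound 1 at 37000 nM and no order can be read between them. Compound 3 `CCCSS/C=C/C[S+]([O-])CCC` differs from compound 2 by ethyl in place of hydrogen on a saturated chain carbon bound to a sulfur as the change, ethyl in place of hydrogen on a saturated chain carbon bound to a sulfur, or methylsulfanyl to propylsulfanyl. For the measured compounds named here, the only measured step at that place is hydrogen in place of vinyl, a 1.3-fold lower number from compound 1 to compound 2 (0.12 log units; within the scatter) as its size. One step is thin evidence, but on that basis no step beyond the scatter is expected in this assay in either direction. The expected step is a 1.1-fold higher number from compound 2 to compound 3 (0.06 log units; within the scatter) and stays within the scatter. Compound 3 is estimated at 32000 nM with an expected range of 16000 nM to 60000 nM for now.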

Compound 3, half-maximal inhibitory concentration: 24000 nM
Beside the measured number, compound 3's estimate is 1.3-fold (0.12 log units) above it; low and high end bracket the measured number.
By their numbers in this assay, from the lowest: compounds 3, 2 and 1 (each within the scatter of the next).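

In this assay the move to propylsulfanyl gives a 1.2-fold lower number from compound 2 to compound 3 (0.07 log units; within the scatter) and so shows no readable effect: ethyl in place of hydrogen on a saturated chain carbon bound to a sulfur joins the earlier vinyl comparison as a second change at this place that stays inside the noise. Ethyl in place of vinyl gives a 1.5-fold lower number from compound 1 to compound 3 (0.19 log units; within the scatter) and likewise stays within the scatter, so compound 1, compound 2 and compound 3 cannot be ordered and this place has so far tolerated all three groups without a measurable difference. Nothing on hand offers an explanation for this flat result.

Going by these compounds, whether an amine, a carboxylic acid or a chain longer than propyl at this place would move the number beyond the scatter remains open. The compounds shown also leave open how changes elsewhere on the shared core would read.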